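The source may hold more compounds than are shown below. What is called first, only, known or untested is meant among the compounds shown, and "the series" means these compounds.

Compound 1 `COc1cc(O)cc2c1C(=O)C(O)C(c1ccccc1)O2` reaches only the edge of what a functional assay on HeLa cells (Homo sapiens) for cytotoxicity, read by MTT assay (on this read-out lower numbers stand for stronger inhibition and higher numbers for weaker inhibition), can report: it gives >= 10000 nM, a limit rather than a number. For the measured compounds named here, compound 2 `COc1cc(O)c(C(=O)/C=C/c2ccccc2)c2c1C[C@H](O)[C@@H](c1cc(O)cc(O)c1)O2` gives 7300 nM in this assay, the only number on hand, while the other result sits at the limit of >= 10000 nM in this assay, at which 1 of the 2 values shown sits. Compound 3 `COc1cc(O)c(C(=O)/C=C/c2ccccc2)c2c1C[C@@H](O)[C@H](c1cc(O)cc(O)c1)O2` is not yet measured; (the two compounds have the same atoms and bonds and differ only in configuration as drawn: 2 of 3 stereo elements differ; a stereocentre at a saturated ring carbon is drawn S in compound 2 and R in compound 3; a stereocentre at a saturated ring carbon is drawn R in compound 2 and S in compound 3). Going by the values given here, no measured pair here shows the effect of such a change, so the expected step of a 1.2-fold higher number from compound 2 to compound 3 (0.09 log units; within the scatter) is modest, in no direction beyond the usual scatter. Compound 3 is therefore estimated at 9000 nM, with a range from 3000 nM to 30000 nM.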

Compound 3, half-maximal inhibitory concentration: 7100 nM
Compound 3: the middle estimate sits 1.3-fold (0.10 log units) above what was measured, within the range that was stated.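

In this assay, swapping the drawn configuration at the two saturated ring carbons gives a 1.0-fold lower number from compound 2 to compound 3 (0.01 log units; within the scatter) and so makes no difference that can be told from the scatter. For the compounds shown here, this is the first measured pair here to test such a change, and the comparison is a clean one: the fact that compounds 2 and 3 differ only in the configuration as drawn. Still open, going by these compounds, is whether changing only one of these two stereocentres would leave the number equally unmoved. Also open, on these data alone, is whether an amine added to the shared core would move it beyond the scatter.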